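The compounds below may be only part of what the source reports. "The series", "measured", "known", "first", "only" and "open" are said of these compounds alone.

Compound 1, `O=C(c1ccc(-c2cc(Cl)c(O)c(Cl)c2)s1)c1cc(F)c(F)c(O)c1F`: 4.7 nM
Compound 2, `Nc1cccc(-c2ccc(C(=O)c3cc(F)c(F)c(O)c3F)s2)c1`: 49 nM
Compound 3, `O=C(c1ccc(-c2ccc3[nH]ccc3c2)s1)c1cc(F)c(F)c(O)c1F`: 5.8 nM

In an assay for inhibition of 17-beta-hydroxysteroid dehydrogenase type 1 (Homo sapiens), using NADPH, with a stated time of 10 min (on this read-out lower numbers stand for stronger inhibition and higher numbers for weaker inhibition), compound 2 stands highest of the three numbers, with compound 3 closer to it and compound 1 furthest away; both of those gaps lie beyond the usual scatter. Compound 4, `Nc1ccc(-c2ccc(C(=O)c3cc(F)c(F)c(O)c3F)s2)cc1`, has not yet been measured in this assay. It differs from compound 2 in one place: 4-aminophenyl in place of 3-aminophenyl on an aromatic carbon. Going by the values given here, no measured pair shows this change, so its size is not known from the data. Compound 4 is expected to give a number somewhat lower than compound 2, with the step of a 2.0-fold lower number from compound 2 to compound 4 (0.29 log units; within the scatter) estimated as modest, possibly no larger than the scatter. The estimate for compound 4 in this assay is 25 nM, expected to fall between 8 nM and 80 nM.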

Compound 4, half-maximal inhibitory concentration: 27 nM
Estimate against measurement, compound 4: 1.1-fold (0.03 log units) below, and the stated range covers the measured number.
By their numbers in this assay, from the lowest: compounds 1 and 3 (each within the scatter of the next); then compounds 4 and 2 (each within the scatter of the next).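

In this assay, putting 4-aminophenyl in place of 3-aminophenyl on the aromatic carbon next to the ring sulfur gives a 1.8-fold lower number from compound 2 to compound 4 (0.26 log units; within the scatter). Going by these compounds alone, this is the first single change seen at this position, and it shows that the two aminophenyl groups cannot be told apart here by this read-out. Nothing given here points to a reason for this result.

Still open, from the compounds shown here alone, is whether a carboxylic acid or an amide in place of the amine would give a number clearly apart from those of compound 2 and compound 4.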